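This account rests on a few compounds, and the source may have more. Where it says the series, first, only, none or still open, it means among the compounds named here.

Working notes on the series, read in a functional assay on A549 cells (Homo sapiens) for antiproliferative activity, read by MTT assay, with a stated time of 48 h; a lower number here means a stronger inhibitor, a higher number a weaker inhibitor. Compound 1 `COc1ccc2nc(NC(c3cn(-c4ccccc4)nc3-c3ccc(Cl)cc3)c3c(O)ccc4ccccc34)sc2c1` gives 34500 nM and compound 2 `COc1ccc2nc(NC(c3cn(-c4ccccc4)nc3-c3ccc([N+](=O)[O-])cc3)c3c(O)ccc4ccccc34)sc2c1` gives 22500 nM. Within the data shown here, these two values lie within the scatter of each other, so compound 2 cannot be ranked apart from compound 1 on the numbers so far.

The next step leads to compound 3 `COc1ccc2nc(NC(c3cn(-c4ccccc4)nc3-c3ccc(F)cc3)c3c(O)ccc4ccccc34)sc2c1`, with fluoro in place of nitro on an aromatic carbon, para to a large group: fluoro in place of nitro on an aromatic carbon. Cut one bond further out, the same difference reads 4-nitrophenyl to 4-fluorophenyl.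

Among the measured compounds shown here, only one measured step bears on this place: nitro in place of chloro, which amounts to a 1.5-fold lower number from compound 1 to compound 2 (0.19 log units; within the scatter). For the measured compounds named here, no fluoro compound has a measured value yet, and that single step offers no firm direction. No step beyond the scatter is therefore expected in this assay.

The estimate amounts to an expected 1.3-fold higher number from compound 2 to compound 3 (0.12 log units; within the scatter). For compound 3 the expected value is 30000 nM, with an estimated range from 14000 nM to 60000 nM.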

Compound 3, half-maximal inhibitory concentration: 33600 nM
The estimate for compound 3 lay 1.1-fold (0.05 log units) below the measured number; the range from low to high includes it.
By their numbers in this assay, from the lowest: compounds 2, 3 and 1 (each within the scatter of the next).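

In this assay, the step from nitro to fluoro on this aromatic carbon, para to a large group, gives a 1.5-fold higher number from compound 2 to compound 3 (0.17 log units; within the scatter) and is read together with the step from chloro to fluoro, which gives a 1.0-fold lower number from compound 1 to compound 3 (0.01 log units; within the scatter) in the same series. Fluoro, chloro and nitro therefore cannot be told apart at this place on these numbers, even though the exchange of nitro for fluoro takes 3 heavy atoms down to 1 heavy atom and 2 hydrogen-bond acceptors down to none. No measured property of these compounds is at hand to account for this result.

On these data alone, whether an amine, a carboxylic acid, a methoxy group or a longer alkyl chain at this place would give a step beyond the scatter remains open, as does the value of the plain unsubstituted phenyl ring. All three compounds also share the rest of their structure, so what a change elsewhere on the shared core would do in this assay is left open as well.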